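The source may report more compounds than this note shows. Statements on the series, on what has been measured and on what is new or still open speak of the compounds shown alone.

In a functional assay on HL-60 cells (Homo sapiens) for antiproliferative activity, read by MTT assay, with a stated time of 72 h (a lower number here means a stronger inhibitor, a higher number a weaker inhibitor), compound 1 `CN(C(=O)CCc1ccccc1)c1ccc2[nH]c(-c3n[nH]c4ccccc34)cc2n1` gives 4730 nM. Among the compounds with values here, the only other compound with a number in this assay is compound 2 `CN(C(=O)c1ccccc1)c1ccc2[nH]c(-c3n[nH]c4cc(C#N)ccc34)cc2n1`, which gives 6430 nM, and the gap between that number and the one for compound 1 lies within the usual scatter of repeated measurements, so the two cannot be told apart and neither can be called the stronger or the weaker. Compound 1 thus stands at one of two numbers that agree with each other, both in the micromolar region.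

Compound 3 `CN(c1ccc2[nH]c(-c3n[nH]c4ccccc34)cc2n1)S(=O)(=O)c1ccccc1` shares the core of compound 1 and differs from it in one place: phenylsulfonyl in place of phenethylcarbonyl on a nitrogen on an aromatic ring. The change swaps one acyl group for a sulfonyl group on the same nitrogen and shortens the link to the attached ring. Within the data shown here, no step between two measured compounds shows what this kind of change does in this assay, so the size of the effect can only be guessed from the change itself. A small weakening, of a size near the edge of the scatter, is expected, giving a 1.9-fold higher number from compound 1 to compound 3 (0.28 log units; within the scatter). Compound 3 is therefore estimated at 9000 nM, with a range from 3000 nM to 27000 nM.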

Compound 3, half-maximal inhibitory concentration: 3700 nM
Compound 3: the middle estimate sits 2.4-fold (0.39 log units) above what was measured; the measured number falls inside the stated range.
By their numbers in this assay, from the lowest: compounds 3, 1 and 2 (each within the scatter of the next).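

In this assay the swap of phenethylcarbonyl for phenylsulfonyl gives a 1.3-fold lower number from compound 1 to compound 3 (0.11 log units; within the scatter) and so the two compounds cannot be told apart. Within the data shown here, this is the first comparison in which only the group on this nitrogen differs, and it shows that a carbonyl-linked group with a chain to its benzene ring can be replaced by a sulfonyl-linked one without any change that this read-out can resolve. Nothing measured here explains why the number holds steady across this change.

The compounds shown leave open whether this nitrogen accepts groups of a different kind, such as a plain acetyl, a benzyl with neither carbonyl nor sulfonyl, or a chain ending in an amine or a carboxylic acid. They also leave open whether the same swap would again make no visible difference on a core carrying a nitrile, as compound 2 does, or with a substituent such as chlorine or methoxy on the benzene ring of the phenylsulfonyl group.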